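The source may hold more compounds than are shown below. What is called first, only, known or untested is meant among the compounds shown, and "the series" means these compounds.

Measured so far:
compound 1 `COc1ccc(C(=O)/C=C\Nc2ccc(-c3nc4cc(OC)c(OC)c(OC)c4s3)cc2C)cc1F`, 2900 nM
compound 2 `COc1ccc(C(=O)/C=C\Nc2ccc(-c3nc4cc(OC)c(OC)c(OC)c4s3)cc2C)cc1[N+](=O)[O-]`, 12400 nM
compound 3 `COc1ccc2nc(-c3ccc(N/C=C\C(=O)c4ccc(OC)c([N+](=O)[O-])c4)cc3)sc2c1`, 17600 nM

All three were tested in a functional assay on MDA-MB-231 cells (Homo sapiens) for antiproliferative activity, read by sulforhodamine B assay, with a stated time of 48 h; on this read-out lower numbers stand for stronger inhibition and higher numbers for weaker inhibition. Compound 1 and compound 2 share one core, and the step of a 4.3-fold lower number from compound 2 to compound 1 (0.63 log units; beyond the scatter) came from a single change, (fluoro in place of nitro on an aromatic carbon). Compound 3 carries a different core; how the core of compound 3 differs from that of compound 2 is not broken down here. Compound 3 gives the highest of the three numbers, but its value and that of compound 2 lie within the scatter of each other. Compound 4 `COc1ccc2nc(-c3ccc(N/C=C\C(=O)c4ccc(OC)c(F)c4)cc3)sc2c1` has not yet been measured. Among the measured compounds shown here, it arises from compound 3 by fluoro in place of nitro on an aromatic carbon, the same kind of change as the one from compound 2 to compound 1, made on a different core. For the measured compounds named here, for compound 4 the expected step is a 3.9-fold lower number from compound 3 to compound 4 (0.59 log units; beyond the scatter), because a 4.3-fold lower number from compound 2 to compound 1 (0.63 log units; beyond the scatter) is the only guide available and a similar size is assumed. Compound 4 is therefore estimated at 4500 nM, expected to fall between 1800 nM and 12000 nM.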

Compound 4, half-maximal inhibitory concentration: 1100 nM
Estimate against measurement, compound 4: 4.1-fold (0.61 log units) above; the whole stated range lies above it.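

Putting fluoro in place of nitro lowers the number in this assay on both cores, but here it gives a 16-fold lower number from compound 3 to compound 4 (1.20 log units; beyond the scatter), and the two steps differ by more than the usual scatter: the same change on two cores in this assay, a 4.3-fold lower number (0.63 log units; beyond the scatter) from compound 2 to compound 1 and a 16-fold lower number (1.20 log units; beyond the scatter) from compound 3 to compound 4, 3.7-fold (0.57 log units) apart, beyond the scatter of two such steps. So the direction of the change carried over from one core to the other, while its size did not, and a step seen on one core is only a rough guide to the other. With just two cores, this does not show which difference between them goes with the larger step, or why.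

On these data alone, whether a chloro, a nitrile or an amine in the same place would follow the fluoro step remains open. Also open, as far as these compounds go, is how the step would behave on any further core.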